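The compounds below may be only part of what the source reports. "The series", "measured", "known", "first", "only" and "open" are said of these compounds alone.

The series shares one core, carried by compound 1 `CC(C)c1ccc(-c2nc(SCc3cn(CC(=O)NC(=O)Nc4ccccn4)nn3)nc(Nc3ccc(Cl)cc3)c2C#N)cc1` and compound 2 `CC(C)c1ccc(-c2nc(SCc3cn(CC(=O)NC(=O)Nc4ccccn4)nn3)nc(Nc3cccc(C(F)(F)F)c3)c2C#N)cc1`. For the measured compounds named here, in a functional assay on ECa-109 cells (Homo sapiens) for inhibition, read by MTT assay, with a stated time of 72 h (on this read-out higher numbers stand for weaker inhibition and lower numbers for stronger inhibition), compound 1 gives 11200 nM, and compound 2 gives 24200 nM, the highest of the two numbers so far, with compound 1 its nearest neighbour. Going by the values given here, the only step that has been measured runs a 2.2-fold higher number from compound 1 to compound 2 (0.33 log units; beyond the scatter), a modest shift that nonetheless lies beyond the usual scatter.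

Compound 3 `CC(C)c1ccc(-c2nc(SCc3cn(CC(=O)NC(=O)Nc4ccccn4)nn3)nc(Nc3ccccc3)c2C#N)cc1` is not yet measured. It differs from compound 2 by hydrogen in place of trifluoromethyl on an aromatic carbon. Among the compounds with values here, no measured step removes a group from this ring outright; the step from compound 1 to compound 2 is the only one that touches this ring at all, and it exchanged one substituted phenyl for another. On that basis a return toward the number of compound 1 seems the more likely outcome, though the size of the move is uncertain.

The expectation for compound 3 in this assay is therefore a 1.6-fold lower number from compound 2 to compound 3 (0.21 log units; within the scatter), giving an estimated value of 15000 nM within a range of 6000 nM to 40000 nM.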

Compound 3, half-maximal inhibitory concentration: > 64000 nM
Compound 3: no number, only a limit; the forecaster's own chance of this, stated with the estimate: 10%; at least 4.2-fold (0.63 log units) between middle value and limit.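

In this assay compound 3 sits at a limit of the assay and not at a number, > 64000 nM. Taking away the substituent from the anilino ring therefore weakens inhibition rather than restoring it: hydrogen in place of trifluoromethyl gives an at least 2.6-fold higher number from compound 2 to compound 3 (0.42 log units; beyond the scatter), and hydrogen in place of chloro gives an at least 5.7-fold higher number from compound 1 to compound 3 (0.75 log units; beyond the scatter). The earlier compounds shown here only exchanged one substituted phenyl for another, whereas these steps show that, among the three compounds, both the 4-chlorophenyl and the 3-(trifluoromethyl)phenyl compounds inhibit more strongly than the bare phenyl compound, with none of the three going against this.

The compounds shown leave open how far compound 3 lies past its limit, and so the full size of both steps, as well as whether the gap between compound 1 and compound 2 follows from the group or from where it sits on the ring, since the two changed together. They also leave open whether another group on this phenyl, such as a methoxy group, a fluorine atom or an amine, would keep the inhibition that chloro and trifluoromethyl give.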